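Benzothiazole halogen swap and cytotoxicity on human cells

A few compounds are considered here, and "the series" means these few. Any claim that something is new, unique, unknown or untested is made for them only; others in the source may bear on it.

In an ADME assay on HEK-293T cells (Homo sapiens) for cytotoxicity, read by MTT assay, with a stated time of 72 h (on this read-out lower numbers stand for stronger inhibition and higher numbers for weaker inhibition), compound 1 `O=C(Nc1nc2ccc(Cl)cc2s1)c1cn(-c2ccccc2)nc1-c1ccccc1` gives 21300 nM. Compound 2 `O=C(Nc1nc2ccc(F)cc2s1)c1cn(-c2ccccc2)nc1-c1ccc(Cl)cc1` reaches only the limit of this assay, > 50000 nM, so its position is a limit rather than a number, as noted in the limit of > 50000 nM in this assay, at which 1 of the 2 values shown sits. Compound 3 `O=C(Nc1nc2ccc(Cl)cc2s1)c1cn(-c2ccccc2)nc1-c1ccc(Cl)cc1` differs from compound 2 by chloro in place of fluoro on an aromatic carbon. Among the compounds with values here, no measured pair shows this step on its own; compound 1, which also carries the chloro on its core, sits at 21300 nM, so a small shift toward stronger inhibition is expected. Compound 3 is estimated at 40000 nM, between 15000 nM and 100000 nM. The expected step of an at least 1.2-fold lower number from compound 2 to compound 3 (0.09 log units; that floor lies within the scatter) may well stay within the scatter.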

Compound 3, half-maximal inhibitory concentration: 15700 nM
The estimate for compound 3 lay 2.5-fold (0.41 log units) above the measured number, and the stated range covers the measured number.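

In this assay, the change from 6-fluoro-1,3-benzothiazol-2-yl to 6-chloro-1,3-benzothiazol-2-yl gives an at least 3.1-fold lower number from compound 2 to compound 3 (0.50 log units; beyond the scatter), so the read-out responds to the halogen at this position. Compound 2 stands only at a limit, so this step has a floor and no exact size: the limit of > 50000 nM in this assay, at which 1 of the 3 values shown sits. With the 6-chloro group kept, adding the second chloro gives a 1.4-fold lower number from compound 1 to compound 3 (0.13 log units; within the scatter), so that second change stays within the scatter.

As far as these compounds go, how a methoxy group or an amine at this position would read remains open. Also open, from the compounds shown here alone, is whether the fluoro-to-chloro step carries over to a core without the second chloro.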